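The compounds below may be only part of what the source reports. "The series", "measured", "known", "first", "only" and "open" are said of these compounds alone.

Working notes on the series. The compounds share one core, an aromatic ring bearing a nitrogen that carries a saturated chain carbon and a five-membered ring. Compound 1 `CS(=O)(=O)c1ccccc1NCc1c[nH]cn1` gives 97% in a functional assay for activation of Alpha-1A adrenergic receptor (Homo sapiens) (a higher number here means a larger maximal response, a lower number a smaller maximal response), compound 2 `c1ccc(-c2cnco2)c(NCc2c[nH]cn2)c1` gives 120%, and compound 3 `c1ccc(N2CCCCC2)c(NCC2=NCCN2)c1` gives 114%. Compound 3 stands second highest of the three numbers; compound 2 lies within the scatter of it, and compound 1 lies lower by a margin beyond the scatter. Within the data shown here, the one step between measured compounds that differ in a single place, a number 23 percentage points higher from compound 1 to compound 2 (beyond the scatter), concerns the substituent on the aromatic ring, not the five-membered ring on the chain carbon.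

Compound 4 `c1ccc(N2CCCCC2)c(NCc2c[nH]cn2)c1` is not yet measured. Its change from compound 3 is a group of 5 heavy atoms (3 carbon, 2 nitrogen; one five-membered aromatic ring with 2 hetero atoms) in place of a group of 5 heavy atoms (3 carbon, 2 nitrogen; one five-membered non-aromatic ring with 2 hetero atoms), on a saturated chain carbon bound to a nitrogen on an aromatic ring. Among the measured compounds shown here, no measured step bears on this exchange; compound 1, which carries the entering group, gives 97%, and compound 2, which also carries it, gives 120%, so the group is compatible with a full response. No step beyond the scatter is therefore expected, a number 6 percentage points lower from compound 3 to compound 4 (within the scatter). Compound 4 is estimated at 108%, within 88% to 128%.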

Compound 4, largest response reached (reported as maximum), in percent of the reference or control that the assay uses: 95%
Estimate against measurement, compound 4: 13 percentage points above; the range from low to high includes it.
By their numbers in this assay, from the lowest: compounds 4 and 1 (each within the scatter of the next); then compounds 3 and 2 (each within the scatter of the next).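

In this assay the exchange on the saturated chain carbon now has a measured size with piperidin-1-yl held constant (a number 19 percentage points lower from compound 3 to compound 4 (beyond the scatter)), so 1H-imidazol-4-yl and the non-aromatic five-membered ring are not interchangeable in this pair. With 1H-imidazol-4-yl held constant, the aromatic carbon also separates its substituents: piperidin-1-yl cannot be told from methylsulfonyl (a number 2 percentage points lower from compound 1 to compound 4 (within the scatter)), whereas 1,3-oxazol-5-yl stands apart from piperidin-1-yl (a number 25 percentage points lower from compound 2 to compound 4 (beyond the scatter)). No available observation accounts for either difference.

From the compounds shown here alone, whether the chain-carbon exchange has a similar size with methylsulfonyl or 1,3-oxazol-5-yl on the aromatic carbon remains open. So does the response with morpholin-4-yl or dimethylamino in place of piperidin-1-yl.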